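This account rests on a few compounds, and the source may have more. Where it says the series, first, only, none or still open, it means among the compounds named here.

Of the compounds shown here, three built on one shared core have been tested in an ADME assay on BEAS-2B cells (Homo sapiens) for inhibition, read by MTT assay, with a stated time of 24 h; on this read-out higher numbers stand for weaker inhibition and lower numbers for stronger inhibition. Compound 1 `O=C(Cn1c(=O)c(/C=C\c2ccncc2)nc2ccccc21)Nc1ccccc1` carries an unsubstituted phenyl on the amide-type nitrogen, and in this assay compound 1 gives > 100000 nM, which is a limit of the assay rather than a number. Compound 2 `O=C(Cn1c(=O)c(/C=C\c2ccncc2)nc2ccccc21)Nc1ccc(F)cc1` adds a fluoro on an aromatic carbon, and in this assay compound 2 gives > 100000 nM, again only a limit. Compound 3 `O=C(Cn1c(=O)c(/C=C\c2ccncc2)nc2ccccc21)Nc1ccc(Cl)cc1` carries a chloro in that place, and in this assay compound 3 gives > 100000 nM, also a limit. Compound 3 thus stands at the same limit as its two companions, all three resting there (the limit of > 100000 nM in this assay, at which 3 of the 3 values shown sit). The steps among them, a step that the two limits leave unreadable from compound 1 to compound 2, a step that the two limits leave unreadable from compound 1 to compound 3 and a step that the two limits leave unreadable from compound 2 to compound 3, are of a size the limits leave unreadable.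

Compound 4 `Cc1ccccc1NC(=O)Cn1c(=O)c(/C=C\c2ccncc2)nc2ccccc21` is the next member, differing from compound 3 by 2-methylphenyl in place of 4-chlorophenyl on an amide-type nitrogen. Among the measured compounds shown here, none of the measured steps offers a readable size, so no direction can be taken from them; what the three values do show is that exchanging hydrogen, fluoro and chloro on this ring has not brought any compound under the limit. Compound 4 is therefore expected to move only a little, a step that the limit leaves unreadable from compound 3 to compound 4. Compound 4 is expected to give 150000 nM in this assay, within a range from 70000 nM to 320000 nM.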

Compound 4, half-maximal inhibitory concentration: > 100000 nM
Compound 4 was reported as a limit; the forecaster's own chance of this, stated with the estimate: 85%; the middle value does not contradict the limit.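

In this assay compound 4 rests at the same limit as compound 1, compound 2 and compound 3, and the steps from those three to compound 4 cannot be read. Left open is whether any other group on the amide-type nitrogen could bring a value under that limit, and how these four compounds truly compare.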